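The source may report more compounds than this note shows. Statements on the series, on what has been measured and on what is new or still open speak of the compounds shown alone.

Measured compounds in a physicochemical assay for solubility, using the shake flask method, in phosphate buffer, with a stated time of 24 h, at pH 7.4; a higher number here means a more soluble compound, a lower number a less soluble compound:
compound 1 `CC(Sc1nc2c(cnn2C)c(=O)n1-c1ccccc1)c1ccccn1` — 20000 nM
compound 2 `Cn1ncc2c(=O)n(-c3ccccc3)c(/C=C/c3cccc(F)c3)nc21` — 4000 nM
compound 3 `Cn1ncc2c(=O)n(-c3ccccc3)c(CNc3cccc(F)c3)nc21` — 64000 nM

Compound 1 stands second highest of the three measured values in this assay. Its nearest neighbour is compound 3, whose value sits higher by a margin beyond the scatter; furthest from it is compound 2, lower by a margin that is also beyond the scatter. Among the measured compounds shown here, no two of the measured compounds differ in one place only, so no single-change step is available as a guide.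

The compound to be measured is compound 4 `CC(Sc1nc2c(cnn2C)c(=O)n1-c1ccccc1)c1cncnc1`. It differs from compound 1 in one place: pyrimidin-5-yl in place of pyridin-2-yl on a saturated chain carbon bound to a saturated chain carbon and a sulfur. The shared core, the sulfur link and the saturated chain are untouched.

Without a matching measured step, the expectation rests on compound 1 alone, anchored on its 20000 nM. The step expected here, a 1.8-fold higher number from compound 1 to compound 4 (0.24 log units; within the scatter), is a modest rise in solubility, possibly no larger than the scatter. Compound 4 is thus estimated at 35000 nM, with a range of 12000 nM to 100000 nM.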

Compound 4, solubility: 264000 nM
Compound 4: the middle estimate sits 7.5-fold (0.88 log units) below what was measured; measured number outside the range, above it.
By their numbers in this assay, from the lowest: compound 2; then compound 1; then compound 3; then compound 4.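

In this assay the exchange of pyridin-2-yl for pyrimidin-5-yl on a saturated chain carbon bound to a saturated chain carbon and a sulfur is a 13-fold higher number from compound 1 to compound 4 (1.12 log units; beyond the scatter) and places compound 4 highest of the four compounds in this series, so the identity of the aromatic ring at this position matters for this read-out. The two groups are close in what can be counted: each is a six-membered aromatic ring of 6 heavy atoms with no net charge and no hydrogen-bond donors, and the entering group holds 2 hetero atoms and 2 hydrogen-bond acceptors against 1 of each in the leaving group. No measured data on these compounds account for the size of this step.

On these data alone, it remains open whether the step depends on the second ring nitrogen or on where the ring nitrogens stand, a question that pyridin-3-yl or pyrazin-2-yl at the same place would address. As far as these compounds go, it is also open whether a pyrimidin-5-yl group would give a similar step on the other links seen in compound 2 and compound 3.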